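Adding a Second Hydroxy Group to a Thienyl Coumarin

The source may hold more compounds than are shown below. What is called first, only, known or untested is meant among the compounds shown, and "the series" means these compounds.

Compound 1 `O=c1oc2c(O)c(O)ccc2cc1-c1cccs1`: 3230 nM
Compound 2 `O=c1oc2c(O)cccc2cc1-c1ccsc1`: 5920 nM

In an assay on CHO cells for displacement of a labelled ligand from adenosine receptor A1 (Homo sapiens) (a lower number here means a stronger inhibitor, a higher number a weaker inhibitor), compound 2 gives 5920 nM, a number that lies within the scatter of the value of compound 1, so the two cannot be told apart. Compound 3 `O=c1oc2c(O)c(O)ccc2cc1-c1ccsc1` carries hydroxy in place of hydrogen on an aromatic carbon. For the measured compounds named here, no single step between measured compounds shows what this change does on the shared core, so the expected step from compound 2 to compound 3 in this assay is small and, in the estimate, does not exceed the scatter, with a 1.5-fold lower number from compound 2 to compound 3 (0.17 log units; within the scatter). Compound 3 is expected to give 4000 nM, within 1500 nM to 11000 nM.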

Compound 3, inhibition constant: 3360 nM
Beside the measured number, compound 3's estimate is 1.2-fold (0.08 log units) above it; low and high end bracket the measured number.
By their numbers in this assay, from the lowest: compounds 1, 3 and 2 (each within the scatter of the next).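

In this assay, hydroxy in place of hydrogen on an aromatic carbon, ortho to a hydroxy group, gives a 1.8-fold lower number from compound 2 to compound 3 (0.25 log units; within the scatter) and so leaves compound 2 and compound 3 indistinguishable on the shared core. Thiophen-3-yl in place of thiophen-2-yl on an aromatic carbon gives a 1.0-fold higher number from compound 1 to compound 3 (0.02 log units; within the scatter) and likewise separates neither compound from the other. No measurement at hand bears on why these values lie so close. Going by these compounds, how an amine or a carboxylic acid in place of this hydroxy group would read remains open.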